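A few compounds are considered here, and "the series" means these few. Any claim that something is new, unique, unknown or untested is made for them only; others in the source may bear on it.

Of the compounds shown here, two built on one shared core have been measured in a functional assay with Rattus norvegicus as the target; on this read-out higher numbers stand for weaker inhibition and lower numbers for stronger inhibition. Compound 1 `CN(C)c1cccc(C(=O)/C=C/c2ccncc2)c1` gives 19000 nM in this assay. Compound 2 `O=C(/C=C/c1ccncc1)c1cccs1` gives 30000 nM in this assay, a number that lies within the usual scatter of the value for compound 1, so neither can be called the stronger inhibitor. Compound 3 `Cc1cccc(C(=O)/C=C/c2ccncc2)c1` has not yet been measured. Its difference from compound 1 is methyl in place of dimethylamino on an aromatic carbon. Among the compounds with values here, no measured pair shows this change, so no step beyond the scatter is expected in either direction. Compound 3 is expected to give about 25000 nM, between 8000 nM and 75000 nM. The expected step, a 1.3-fold higher number from compound 1 to compound 3 (0.12 log units; within the scatter), stays within the scatter.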

Compound 3, half-maximal inhibitory concentration: 39000 nM
Compound 3: the middle estimate sits 1.6-fold (0.19 log units) below what was measured; the measured number falls inside the stated range.
By their numbers in this assay, from the lowest: compounds 1, 2 and 3 (each within the scatter of the next, the first and the last beyond it).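

In this assay, putting methyl in place of dimethylamino on this aromatic carbon gives a 2.1-fold higher number from compound 1 to compound 3 (0.31 log units; beyond the scatter), so the group at this position does affect the read-out, though only modestly, and inhibition is weaker with methyl. This single pair gives no measured information on why the number rises. Still open, from the compounds shown here alone, is how a plain amino group or a carboxylic acid on this same carbon would compare with dimethylamino and methyl. Also open, going by these compounds, is whether the same change would give a similar step on a different core.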